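Freeing one hydroxyl on the hydrazone aryl ring

The source may hold more compounds than are shown below. What is called first, only, known or untested is meant among the compounds shown, and "the series" means these compounds.

Three hydrazones sharing one core have been tested in an assay on isolated protein for inhibition of Maltase-glucoamylase (Homo sapiens), with a stated time of 15 min; a lower number here means a stronger inhibitor, a higher number a weaker inhibitor. Compound 1 `O=C(N/N=C/c1ccc(O)cc1)c1ccc(-c2nc3ccccc3s2)cc1` carries a 4-hydroxyphenyl on the carbon with a double bond to nitrogen, and in this assay compound 1 gives 11300 nM. Compound 2 `COc1ccc(/C=N/NC(=O)c2ccc(-c3nc4ccccc4s3)cc2)c(O)c1` carries a 2-hydroxy-4-methoxyphenyl there instead, and compound 2 gives 6970 nM; the step of a 1.6-fold lower number from compound 1 to compound 2 (0.21 log units; within the scatter) lies within the scatter. Compound 3 `COc1ccc(/C=N/NC(=O)c2ccc(-c3nc4ccccc4s3)cc2)cc1OC` carries a 3,4-dimethoxyphenyl, and for compound 3 this assay reports "not active" (no number reported), so no single number is available for it; it stands apart from compounds 1 and 2, which both gave measurable numbers.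

Compound 4 `COc1cc(/C=N/NC(=O)c2ccc(-c3nc4ccccc4s3)cc2)ccc1O` differs from compound 3 in one place: hydrogen in place of methyl on an oxygen on an aromatic ring. For the measured compounds named here, no measured step matches this exact change. What the data do show is that both compounds carrying a hydroxy on that ring, compound 1 and compound 2, gave numbers in this assay, whereas compound 3, without one, did not. Compound 4 regains a hydroxy, so a measurable but weak number, of the size seen for compound 1, is expected. Compound 4 is therefore estimated at 11000 nM, with a range from 4000 nM to 35000 nM.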

Compound 4, half-maximal inhibitory concentration: 53300 nM
Compound 4: middle estimate off by 4.8-fold (0.69 log units), on the low side; measured number outside the range, above it.
By their numbers in this assay, from the lowest: compounds 2 and 1 (each within the scatter of the next); then compound 4.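

In this assay, the same two oxygen groups arranged differently do not give the same result: 4-hydroxy-3-methoxyphenyl in place of 2-hydroxy-4-methoxyphenyl gives a 7.6-fold higher number from compound 2 to compound 4 (0.88 log units; beyond the scatter) and is a real loss, not noise. A hydroxy on this ring is therefore no guarantee of a number near those of the two earlier hydroxy compounds, and the earlier idea that simply having one is enough does not hold for compound 4, even though it does give a measurable number. Adding a methoxy to the 4-hydroxyphenyl ring also goes the wrong way, with a 4.7-fold higher number from compound 1 to compound 4 (0.67 log units; beyond the scatter) as the result, and no measurement shown here explains either loss.

Going by these compounds, the step between compound 3 and compound 4 cannot be read, since compound 3 has no number, so the size of the change from methoxy to hydroxy on this ring stays unknown. Also open, on these data alone, is whether an amine or a carboxylic acid in place of the hydroxy on this ring would give a lower number than the hydroxy compounds do.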